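The source may hold more compounds than are shown below. What is called first, only, known or untested is meant among the compounds shown, and "the series" means these compounds.

Measured so far:
- compound 1 `N#Cc1ccc(C(=O)Nc2ccc(-c3nn[nH]n3)cc2)cc1`: 54.4 mg/kg
- compound 2 `CCCCc1ccc(C(=O)Nc2cc(C(=O)O)cc(C(=O)O)c2)cc1`: 91.9 mg/kg
- compound 3 `COc1cc(OC)cc(C(=O)Nc2cc(C(=O)O)cc(C(=O)O)c2)c1`: 108 mg/kg

In a functional assay on the whole organism (stomach) with Rattus norvegicus as the target (on this read-out higher numbers stand for an effect only at larger amounts of compound and lower numbers for an effect already at smaller amounts), compound 2 gives 91.9 mg/kg, which lies within the scatter of both compound 1 and compound 3, so the three numbers support no ranking.

The next step leads from compound 2 to compound 4 `N#Cc1ccc(C(=O)Nc2cc(C(=O)O)cc(C(=O)O)c2)cc1`: cyano in place of butyl on an aromatic carbon. This puts cyano in place of butyl on an aromatic carbon, para to a large group. Among the measured compounds shown here, no measured pair isolates this change, so the evidence is indirect. Compound 2 and compound 3 share one core and differ in their substituents, yet compound 3 at 108 mg/kg stays within the scatter of compound 2. For the measured compounds named here, compound 1, the only measured compound with a cyano group, gives 54.4 mg/kg on a different core and also stays within that scatter.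

The estimated step of a 1.1-fold lower number from compound 2 to compound 4 (0.06 log units; within the scatter) is expected to stay within the scatter, with no firm direction. The expected value for compound 4 is 80 mg/kg, with an estimated range of 40 mg/kg to 160 mg/kg.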

Compound 4, dose for 50% inhibition: 32.1 mg/kg
Compound 4: middle estimate off by 2.5-fold (0.40 log units), on the high side; the measured number lies below the stated range.
By their numbers in this assay, from the lowest: compounds 4, 1, 2 and 3 (each within the scatter of the next, the first and the last beyond it).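

In this assay, among the compounds shown here, the position para to a large group gives the first readable single change: cyano in place of butyl on an aromatic carbon gives a 2.9-fold lower number from compound 2 to compound 4 (0.46 log units; beyond the scatter) on the shared core. The earlier compounds shown here included no pair differing in one place, whereas this step shows that the number responds to the group at this position, with the cyano compound needing the smaller amount. No measurement shown here accounts for the step.

This is one modest step from a single pair, so it sets no trend across substituents at this position. Still open, as far as these compounds go, is how an ethyl chain, an amine or a carboxylic acid at this position would compare with cyano and butyl on the shared core.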